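Plasma binding when ethoxy replaces 1,1-difluoropropyl

The compounds below may be only part of what the source reports. "The series", "measured", "known", "first", "only" and "open" are said of these compounds alone.

- compound 1 `CCOc1nc2nc(C)cc(Nc3ccc(C(F)(F)F)cc3)n2n1` measured at 92.4% 
- compound 2 `CCC(F)(F)c1nc2nc(C)cc(Nc3ccc(S(F)(F)(F)(F)F)cc3)n2n1` measured at 97.7% 

Both values come from an ADME assay on a cell-free system (plasma, Homo sapiens) for protein binding, and both compounds are heavily bound. Compound 2 stands higher of the two, with the lowest unbound fraction, and compound 1 has a higher unbound fraction by a gap beyond the scatter. Compound 3 `CCOc1nc2nc(C)cc(Nc3ccc(S(F)(F)(F)(F)F)cc3)n2n1` has not yet been measured. It carries ethoxy in place of 1,1-difluoropropyl on an aromatic carbon and keeps the rest of compound 2 unchanged. Among the measured compounds shown here, no measured pair differs in one place only, so the data give no direct size for this change. For the measured compounds named here, the only lower reference is compound 1 at 92.4% and so a modest move toward more free compound is expected, perhaps no larger than the scatter. The estimated change is a 1.7-fold higher unbound fraction from compound 2 to compound 3 (0.24 log units; within the scatter) in unbound fraction. Compound 3 is expected at 96% with an estimated range from 93% to 98% in this assay overall.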

Compound 3, plasma protein binding in the plasma assay: 97.7%
Estimate against measurement, compound 3: 1.7-fold (0.24 log units) (unbound fraction) above; measured number inside the range.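

In the plasma assay, ethoxy in place of 1,1-difluoropropyl on this aromatic carbon, between two ring nitrogen atoms, gives no change at the digits printed from compound 2 to compound 3 (within the scatter). With ethoxy kept, the group of 6 heavy atoms in place of the group of 4 heavy atoms gives in the plasma assay a 3.3-fold lower unbound fraction from compound 1 to compound 3 (0.52 log units; beyond the scatter), which places a step beyond the scatter at that second site and not at this one. The same ethoxy change does separate the two compounds in a physicochemical assay for solubility, at pH 6.5 (a higher number here means a more soluble compound, a lower number a less soluble compound), with compound 2 at 15000 nM and compound 3 at 4000 nM: the measured solubility of compound 2, 15000 nM, and of compound 3, 4000 nM, a 3.8-fold lower number (0.57 log units; beyond the scatter)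

The compounds shown leave open whether an amine or a longer chain on this aromatic carbon would also leave the reading in the plasma assay unchanged. They also leave open whether the step at the second site keeps its size with 1,1-difluoropropyl in place of ethoxy.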